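The source may report more compounds than this note shows. Statements on the series, on what has been measured and on what is new or still open speak of the compounds shown alone.

Measured so far:
- compound 1, `CCc1ccc(N(Cc2ccccc2)S(=O)(=O)c2ccc3c(c2)C(=O)CC(C2CCOCC2)O3)cc1`, gives 4.84 in a physicochemical assay for lipophilicity, at pH 7.4; on this read-out higher numbers stand for higher lipophilicity and lower numbers for lower lipophilicity
- compound 2, `Cc1ccc(NS(=O)(=O)c2ccc3c(c2)C(=O)CC(C2CCOCC2)O3)c(C)c1`, gives 2.75 in this assay
- compound 3, `Cc1ccc(N(CC(C)C)S(=O)(=O)c2ccc3c(c2)C(=O)CC(C2CCOCC2)O3)c(C)c1`, gives 4.28 in this assay

Compound 3 stands second highest of the three numbers; compound 1 lies higher than it and compound 2 lies lower, both beyond the scatter. Going by the values given here, the only step measured between two compounds that differ in one place is a number 1.53 log units higher from compound 2 to compound 3 (beyond the scatter), which shows how much a larger group on the sulfonamide nitrogen can raise the read-out.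

Compound 4, `CC(C)CN(c1ccc(C(C)(C)C)cc1)S(=O)(=O)c1ccc2c(c1)C(=O)CC(C1CCOCC1)O2`, has not yet been measured. It differs from compound 3 in one place: 4-(tert-butyl)phenyl in place of 2,4-dimethylphenyl on a sulfonamide nitrogen. Among the compounds with values here, no measured step covers this exact exchange, so the expectation rests on the fact that the entering group is larger than the leaving one, and on the step from compound 2 to compound 3, where adding carbon atoms at this nitrogen raised the number. A moderate rise is therefore expected, estimated as a number 0.57 log units higher from compound 3 to compound 4 (beyond the scatter). Compound 4 is expected to give about 4.85, within a range of 4.4 to 5.35.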

Compound 4, distribution coefficient: 4.97
The estimate for compound 4 lay 0.12 log units below the measured number; low and high end bracket the measured number.
By their numbers in this assay, from the lowest: compound 2; then compound 3; then compounds 1 and 4 (each within the scatter of the next).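

The earlier step changed what sits on the sulfonamide nitrogen in place of a hydrogen, whereas this one shows that the aromatic group on that nitrogen also moves the read-out: with the isobutyl group kept, 4-(tert-butyl)phenyl in place of 2,4-dimethylphenyl gives, in this assay, a number 0.69 log units higher from compound 3 to compound 4 (beyond the scatter). The entering group has 10 heavy atoms and the leaving group 8, all carbon, so this rise accompanies a small gain in carbon, a link seen in this one pair only. Nothing available explains the rise.

On these data alone, the exchange removes two methyl groups and brings in a tert-butyl group at once, so the share of each remains unknown. Also open, as far as these compounds go, is how the number would respond to a carboxylic acid or an amine on this aromatic ring.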